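Swapping naphthalen-1-yl for cyclopropyl: compound 3 to compound 4

The source may report more compounds than this note shows. Statements on the series, on what has been measured and on what is new or still open speak of the compounds shown alone.

Measured in a functional assay on MGC-803 cells (Homo sapiens) for inhibition, read by MTT assay, with a stated time of 72 h; on this read-out higher numbers stand for weaker inhibition and lower numbers for stronger inhibition:
- compound 1 `Cc1cc(Nc2cc(-c3ccccc3)[nH]n2)n2nc(SCCCc3ccccc3)nc2n1`: 6510 nM
- compound 2 `Cc1cc(Nc2cc(-c3ccccc3)[nH]n2)n2nc(SCc3nc4ccccc4[nH]3)nc2n1`: 1790 nM
- compound 3 `Cc1cc(Nc2cc(-c3ccccc3)[nH]n2)n2nc(SCc3cccc4ccccc34)nc2n1`: 3120 nM

Compound 3 holds the second highest of the three numbers, within the scatter of compound 2 and beyond it from compound 1. Compound 4 `Cc1cc(Nc2cc(-c3ccccc3)[nH]n2)n2nc(SCC3CC3)nc2n1` carries cyclopropyl in place of naphthalen-1-yl on a saturated chain carbon bound to a sulfur. Two measured steps at this place bear on the change: a 2.1-fold lower number from compound 1 to compound 3 (0.32 log units; beyond the scatter) and a 1.7-fold higher number from compound 2 to compound 3 (0.24 log units; within the scatter). Both are modest, but neither brings in a group as small as cyclopropyl. Expected in this assay is a 1.6-fold higher number from compound 3 to compound 4 (0.20 log units; within the scatter), a step that leans upward without clearly leaving the scatter. For compound 4 the estimated value is 5000 nM, with an expected range of 1800 nM to 14000 nM.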

Compound 4, half-maximal inhibitory concentration: 16100 nM
The estimate for compound 4 lay 3.2-fold (0.51 log units) below the measured number, outside the stated range (above it).
By their numbers in this assay, from the lowest: compounds 2 and 3 (each within the scatter of the next); then compound 1; then compound 4.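

In this assay cyclopropyl on a saturated chain carbon bound to a sulfur gives a 5.2-fold higher number from compound 3 to compound 4 (0.71 log units; beyond the scatter) and a 9.0-fold higher number from compound 2 to compound 4 (0.95 log units; beyond the scatter) and these two exceed every earlier step at this place. Even against phenethyl it gives a 2.5-fold higher number from compound 1 to compound 4 (0.39 log units; beyond the scatter) so this position is not indifferent to its group, and among these four compounds cyclopropyl gives the highest number, with no compound going against that. Nothing measured here explains this result.

As far as these compounds go, whether the ring type or the group's size tracks with the number stays open. A plain phenyl or a hexyl chain at this place would help separate the two.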